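A few compounds are considered here, and "the series" means these few. Any claim that something is new, unique, unknown or untested is made for them only; others in the source may bear on it.

In a functional assay on HeLa cells (Homo sapiens) for antiproliferative activity, read by MTT assay, with a stated time of 72 h (on this read-out lower numbers stand for stronger inhibition and higher numbers for weaker inhibition), compound 1 `Cc1ccc2c(=O)c(CSC(=S)N3CCCCC3)coc2c1` gives > 25000 nM, and this is a limit of the assay rather than a measured number, since compound 1 sits at the limit of > 25000 nM in this assay, at which 1 of the 2 values shown sits. Compound 2 `COc1ccc2oc(CSC(=S)N3CCCCC3)cc(=O)c2c1` gives 11900 nM in this assay. Compound 3 `Cc1ccc2c(=O)c(CSC(=S)N3CCCC3)coc2c1` differs from compound 1 by pyrrolidin-1-yl in place of piperidin-1-yl on a thiocarbonyl carbon. Among the compounds with values here, no measured pair follows this change, so in this assay the step is expected to stay within the usual scatter, with no direction beyond it. Compound 3 is therefore estimated at 30000 nM, between 10000 nM and 100000 nM, an expected step that the limit leaves unreadable from compound 1 to compound 3.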

Compound 3, half-maximal inhibitory concentration: 4400 nM
Estimate against measurement, compound 3: 6.8-fold (0.83 log units) above, and the stated range ends above it.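

The thiocarbonyl carbon proves to be a place where the attached amine ring matters: in this assay, pyrrolidin-1-yl in place of piperidin-1-yl gives an at least 5.6-fold lower number from compound 1 to compound 3 (0.75 log units; beyond the scatter). The earlier compounds shown here offered no pair that could show this. The true size of the step stays open, since the value for compound 1 is a limit and not a number: the limit of > 25000 nM in this assay, at which 1 of the 3 values shown sits.

The compounds shown leave open how a morpholin-4-yl ring or an open-chain diethylamino group would read at this thiocarbonyl carbon. They also leave open whether the same exchange holds on the core of compound 2.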